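From Phenyl to 4-Bromophenyl at the Assay Limit

The source may report more compounds than this note shows. Statements on the series, on what has been measured and on what is new or still open speak of the compounds shown alone.

In a functional assay on cells (Homo sapiens) for inhibition, read by MTT assay, with a stated time of 72 h (on this read-out higher numbers stand for weaker inhibition and lower numbers for stronger inhibition), compound 1 `CCOC(=O)Cn1ncc2c(Nc3ccc(NS(=O)(=O)c4ccccc4)cc3)ncnc21` gives > 100 ug/mL, which is a limit and not a number. Compound 2 `O=C(O)Cn1ncc2c(Nc3ccc(NS(=O)(=O)c4ccc([N+](=O)[O-])cc4)cc3)ncnc21` gives > 100 ug/mL, also a limit. Compound 3 `O=C(O)Cn1ncc2c(Nc3ccc(NS(=O)(=O)c4ccccc4)cc3)ncnc21` gives > 100 ug/mL, again a limit. Compound 1 therefore stands alongside the other two, and none of the three carries a number.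

Compound 4 `CCOC(=O)Cn1ncc2c(Nc3ccc(NS(=O)(=O)c4ccc(Br)cc4)cc3)ncnc21` differs from compound 1 by bromo in place of hydrogen on an aromatic carbon, which turns phenylsulfonyl into (4-bromophenyl)sulfonyl. For the measured compounds named here, two measured steps bear on this change. The closer one places hydrogen in place of nitro on an aromatic carbon, and it is a step that the two limits leave unreadable from compound 2 to compound 3. The other places hydrogen in place of ethyl on an oxygen next to a carbonyl group, and it is a step that the two limits leave unreadable from compound 1 to compound 3. Neither gives a size or a direction, so no shift beyond the scatter is expected in this assay. The expected outcome is a number no higher from compound 1 to compound 4 (the limit leaves the size open). Compound 4 is estimated at 100 ug/mL, with an expected range from 40 ug/mL to 250 ug/mL.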

Compound 4, half-maximal inhibitory concentration: > 64 ug/mL
Compound 4 gave a limit, no number; the forecaster's own chance of this, stated with the estimate: 65%; the middle value is on the limit's open side.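

Compound 1 and compound 4 both give limits and no numbers, so the change from phenyl to 4-bromophenyl yields no readable step. The compounds shown leave open what size or direction, if any, this change has in this assay.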